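Sulfonyl in place of benzyl on the ring nitrogen: compound 4

The compounds below may be only part of what the source reports. "The series", "measured", "known", "first", "only" and "open" are said of these compounds alone.

Measured so far in a functional assay on NALM-6 cells (Homo sapiens) for antiproliferative activity, read by MTT assay and trypan blue exclusion, with a stated time of 72 h; a lower number here means a stronger inhibitor, a higher number a weaker inhibitor:
Compound 1, `COC(=O)c1ccc(C2SCC(=O)N2c2ccc(N3CCN(Cc4cccc([N+](=O)[O-])c4)CC3)cn2)c(OC)c1`, sits at the limit of > 100000 nM.
Compound 2, `COC(=O)c1ccc(C2SCC(=O)N2c2ccc(N3CCN(Cc4cccc(C)c4)CC3)cn2)c(OC)c1`, gives 27300 nM.
Compound 3, `COC(=O)c1ccc(C2SCC(=O)N2c2ccc(N3CCN(S(=O)(=O)c4ccc([N+](=O)[O-])cc4)CC3)cn2)c(OC)c1`, sits at the limit of > 100000 nM.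

Among the compounds with values here, compound 2 holds the only actual number in this assay; the other two values are limits, as the limit of > 100000 nM in this assay, at which 2 of the 3 values shown sit, records. The methyl in place of nitro on an aromatic carbon gives an at least 3.6-fold lower number from compound 1 to compound 2 (0.56 log units; beyond the scatter). Replacing the 3-methylbenzyl by (4-nitrophenyl)sulfonyl gives an at least 3.6-fold higher number from compound 2 to compound 3 (0.56 log units; beyond the scatter), while a step that the two limits leave unreadable from compound 1 to compound 3 cannot be read because both ends are limits.

Compound 4, `COC(=O)c1ccc(C2SCC(=O)N2c2ccc(N3CCN(S(=O)(=O)c4cc(Cl)ccc4Cl)CC3)cn2)c(OC)c1`, differs from compound 2 by (2,5-dichlorophenyl)sulfonyl in place of 3-methylbenzyl on an amine nitrogen in a ring.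

Within the data shown here, the step that bears on this change is the one from compound 2 to compound 3, where a sulfonyl-linked aryl took the place of the benzyl on the same ring nitrogen and the number rose beyond the scatter. Compound 4 carries a sulfonyl-linked aryl of the same kind, so a weakening of comparable size is expected, with a real chance that this assay again reports only a limit. Compound 4 is therefore expected to give about 80000 nM, within 30000 nM to 200000 nM. This expected step is a 2.9-fold higher number from compound 2 to compound 4 (0.47 log units; beyond the scatter).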

Compound 4, half-maximal inhibitory concentration: 27400 nM
For compound 4 the middle estimate is 2.9-fold (0.47 log units) above the measured one; the whole stated range lies above it.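

In this assay, a sulfonyl link on the ring nitrogen does not by itself separate a compound from the benzyl series: (2,5-dichlorophenyl)sulfonyl in place of 3-methylbenzyl gives a 1.0-fold higher number from compound 2 to compound 4 (0.00 log units; within the scatter), so the two groups cannot be told apart here. With the sulfonyl link held fixed, the aryl group on it matters, as 2,5-dichlorophenyl in place of 4-nitrophenyl on the sulfonyl sulfur gives an at least 3.6-fold lower number from compound 3 to compound 4 (0.56 log units; beyond the scatter), and the loss seen with compound 3 therefore cannot be assigned to the sulfonyl link alone. The comparison with the 3-nitrobenzyl group points the same way, with an at least 3.6-fold lower number from compound 1 to compound 4 (0.56 log units; beyond the scatter), and this step and the previous one are bounds only, each starting from a limit: the limit of > 100000 nM in this assay, at which 2 of the 4 values shown sit.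

The step between compound 1 and compound 3 cannot be read, both of its ends being limits. The compounds shown leave open whether the nitro group or the chlorines govern the sulfonyl aryl's effect, a question that an unsubstituted phenyl, a single chlorine or an amine on that ring would address.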